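The compounds below may be only part of what the source reports. "The series", "measured", "known", "first", "only" and "open" are said of these compounds alone.

Compound 1 `CCCN(CC1CC1)c1nc(C)nc2c(-c3ccc(Cl)cc3Cl)c(C)nn12` gives 0.7 nM in an assay on isolated protein for displacement of a labelled ligand from corticotropin-releasing factor receptor 1 (Homo sapiens) (a lower number here means a stronger inhibitor, a higher number a weaker inhibitor), the highest of the three numbers shown, though compound 2 `CCCN(CCC)c1nc(C)nc2c(-c3ccc(Cl)cc3Cl)c(C)nn12` with 0.6 nM and compound 3 `CCCCN(CC)c1nc(C)nc2c(-c3ccc(Cl)cc3Cl)c(C)nn12` with 0.4 nM both lie within the scatter of it. Compound 4 `CCN(CC)c1nc(C)nc2c(-c3ccc(Cl)cc3Cl)c(C)nn12` differs from compound 1 by diethylamino in place of (cyclopropylmethyl)(propyl)amino on an aromatic carbon. Among the compounds with values here, the steps that bear on this change are a 1.2-fold lower number from compound 1 to compound 2 (0.07 log units; within the scatter), a 1.8-fold lower number from compound 1 to compound 3 (0.24 log units; within the scatter) and a 1.5-fold lower number from compound 2 to compound 3 (0.18 log units; within the scatter); each reshaped the same amino group without moving the number beyond the scatter. Diethylamino carries fewer heavy atoms than any of the measured groups, so a modest loss cannot be ruled out, yet no step beyond the scatter is expected, a 2.1-fold higher number from compound 1 to compound 4 (0.33 log units; beyond the scatter). Compound 4 is therefore estimated at 1.5 nM, within a range from 0.5 nM to 5 nM.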

Compound 4, inhibition constant: 1.2 nM
For compound 4 the middle estimate is 1.3-fold (0.10 log units) above the measured one; the range from low to high includes it.
By their numbers in this assay, from the lowest: compounds 3, 2, 1 and 4 (each within the scatter of the next, the first and the last beyond it).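

Trimming the amino group to diethylamino gives the first step at this aromatic carbon that passes the scatter, and it does so against compound 3 alone (a 3.0-fold higher number from compound 3 to compound 4 (0.48 log units; beyond the scatter)), where butyl gives way to ethyl. Against the other two, the change stays within the scatter (a 1.7-fold higher number from compound 1 to compound 4 (0.23 log units; within the scatter); a 2.0-fold higher number from compound 2 to compound 4 (0.30 log units; within the scatter)). Nothing available explains this step. The compounds shown leave open how a chain longer than butyl, or a cyclic amine such as morpholine, would fare on this carbon.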